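The source may hold more compounds than are shown below. What is called first, only, known or untested is meant among the compounds shown, and "the series" means these compounds.

Three compounds share one core and differ only in the group carried on the benzyl arm attached to the ring nitrogen. Compound 1 `CCCSc1nc(N/N=C(\C)c2ccccc2O)c2nnn(Cc3ccc(Cl)cc3)c2n1` carries a 4-chlorophenyl there, and in a functional assay on ECa-109 cells (Homo sapiens) for antiproliferative activity, read by MTT assay, with a stated time of 72 h (a lower number here means a stronger inhibitor, a higher number a weaker inhibitor), compound 1 gives 11200 nM. Compound 2 `CCCSc1nc(N/N=C(\C)c2ccccc2O)c2nnn(Cc3ccccc3Cl)c2n1` carries a 2-chlorophenyl instead; in this assay compound 2 reaches only the limit of the assay, > 64000 nM, so no number is known for it (the limit of > 64000 nM in this assay, at which 1 of the 3 values shown sits). Compound 3 `CCCSc1nc(N/N=C(\C)c2ccccc2O)c2nnn(Cc3ccc(O)cc3)c2n1` carries a 4-hydroxyphenyl, and in this assay compound 3 gives 15900 nM. Among the two numbers that are known, compound 3 stands highest, but its only neighbour is compound 1, and the step of a 1.4-fold higher number from compound 1 to compound 3 (0.15 log units; within the scatter) is within the scatter, so the two cannot be ranked. Moving the chloro from one ring position to another gave an at least 5.7-fold higher number from compound 1 to compound 2 (0.75 log units; beyond the scatter).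

Compound 4 `CCCSc1nc(N/N=C(\C)c2ccccc2O)c2nnn(Cc3ccc(F)cc3)c2n1` is not yet measured. It differs from compound 3 by fluoro in place of hydroxy on an aromatic carbon. The measured step that bears most directly on this change is the swap at the same ring position, a 1.4-fold higher number from compound 1 to compound 3 (0.15 log units; within the scatter), which was within the scatter. A further swap of the same kind, from hydroxy to fluoro, is therefore expected to move this assay little, a 1.2-fold lower number from compound 3 to compound 4 (0.09 log units; within the scatter), in no direction beyond the scatter. Compound 4 is expected to give 13000 nM in this assay, within a range from 5500 nM to 32000 nM.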

Compound 4, half-maximal inhibitory concentration: 21900 nM
Compound 4: the middle estimate sits 1.7-fold (0.23 log units) below what was measured; measured number inside the range.
By their numbers in this assay, from the lowest: compounds 1, 3 and 4 (each within the scatter of the next). At a limit, above all of these: compound 2.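

Swapping hydroxy for fluoro at the place para to a large group gives a 1.4-fold higher number from compound 3 to compound 4 (0.14 log units; within the scatter), so in this assay a group counted with one hydrogen-bond donor and one acceptor and a group counted with neither cannot be told apart. For the compounds shown here, the step of a 2.0-fold higher number from compound 1 to compound 4 (0.29 log units; within the scatter) is also within the scatter, which means that hydroxy, fluoro and chloro at this place now form a set of three compounds with no step among them beyond the scatter. Compound 4 also separates from compound 2, an at least 2.9-fold lower number from compound 2 to compound 4 (0.46 log units; beyond the scatter), making it the third compound with a group at this place to do so, but the size of all these gaps stays open, since compound 2 gives only a limit and not a number: the limit of > 64000 nM in this assay, at which 1 of the 4 values shown sits.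

The compounds shown leave open whether an amine, a carboxylic acid or a methoxy at the same place would also stay within the scatter of these three, or whether a phenyl with no added group would. Going by these compounds alone, with 2-chlorophenyl as the only group of its kind, it also remains unknown whether a 2-fluorophenyl or 2-hydroxyphenyl would behave like compound 2 or like compound 4.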